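The source may report more compounds than this note shows. Statements on the series, on what has been measured and on what is new or still open speak of the compounds shown alone.

Compound 3 `COc1ccc(-c2c(-c3cc(OC)c(OC)c(OC)c3)c(=O)c2=O)cc1F` stands lowest of the three numbers seen so far in a functional assay on CCRF-CEM cells (Homo sapiens) for inhibition, read by MTT assay, with a stated time of 72 h; on this read-out lower numbers stand for stronger inhibition and higher numbers for weaker inhibition: compound 3 gives 11.5 nM, while compound 1 `COc1ccc(-c2c(-c3cc(OC)c(OC)c(OC)c3)c(=O)c2=O)cc1OC` gives 210 nM and compound 2 `COc1ccc(-c2c(-c3cc(OC)c(OC)c(OC)c3)c(=O)c2=O)cc1Cl` gives 136 nM. The step of a 12-fold lower number from compound 2 to compound 3 (1.07 log units; beyond the scatter) and the step of an 18-fold lower number from compound 1 to compound 3 (1.26 log units; beyond the scatter) are both large, whereas the step of a 1.5-fold lower number from compound 1 to compound 2 (0.19 log units; within the scatter) is small. Compound 4 `COc1cc(-c2c(-c3ccc4cc[nH]c4c3)c(=O)c2=O)cc(OC)c1OC` differs from compound 3 by 1H-indol-6-yl in place of 3-fluoro-4-methoxyphenyl on an aromatic carbon. For the measured compounds named here, no measured step exchanges this whole ring, so none bears directly on the change; the two large steps onto compound 3 only show that this part of the molecule can move the number a great deal in this assay. A sizeable step is therefore expected, its direction uncertain, with a wide range. Compound 4 is estimated at 100 nM, between 10 nM and 1000 nM, which would mean an 8.7-fold higher number from compound 3 to compound 4 (0.94 log units; beyond the scatter).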

Compound 4, half-maximal inhibitory concentration: 6.6 nM
For compound 4 the middle estimate is 15-fold (1.18 log units) above the measured one; the measured number lies below the stated range.
By their numbers in this assay, from the lowest: compounds 4 and 3 (each within the scatter of the next); then compounds 2 and 1 (each within the scatter of the next).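

In this assay the whole 3-fluoro-4-methoxyphenyl ring can give way to 1H-indol-6-yl, with a ring of a different shape and a hydrogen-bond donor entering, and the step of a 1.7-fold lower number from compound 3 to compound 4 (0.24 log units; within the scatter) stays within the scatter. The low number seen so far therefore does not depend on the fluoro or methoxy group alone, and the indole matches the fluoro compound, while a 21-fold lower number from compound 2 to compound 4 (1.31 log units; beyond the scatter) shows it well clear of the chloro compound. Nothing measured here explains this result. As far as these compounds go, whether the indole hydrogen matters remains open, as a methyl group on the indole nitrogen would test, and so does how an aminophenyl or a pyridine ring would behave in this place.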